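This account rests on a few compounds, and the source may have more. Where it says the series, first, only, none or still open, it means among the compounds named here.

In an ADME assay on TZM cells (Homo sapiens) for cytotoxicity, read by XTT assay, with a stated time of 4 days (a lower number here means that less compound is tolerated, a higher number that more compound is tolerated), compound 1 (`Cc1cc(/C=C/C#N)cc(C)c1Oc1ccc([N+](=O)[O-])c(Nc2ccc(C#N)cc2)c1`) reads > 48700 nM, which is a limit of the assay. Going by the values given here, compound 2 (`Cc1cc(/C=C/C#N)cc(C)c1Oc1ccc(N)c(Nc2ccc(C#N)cc2)c1`) gives 25000 nM, the only actual number so far. Compound 3 (`Cc1cc(/C=C/C#N)cc(C)c1Oc1cc(Nc2ccc(C#N)cc2)c(N)cc1N`) differs from compound 2 by amino in place of hydrogen on an aromatic carbon. One measured step offers a loose guide: amino in place of nitro on an aromatic carbon, an at least 1.9-fold lower number from compound 1 to compound 2 (0.28 log units; that floor lies within the scatter). In this assay, a modest move towards a lower number is therefore expected, possibly none beyond the scatter. The expected step is a 1.4-fold lower number from compound 2 to compound 3 (0.14 log units; within the scatter). For compound 3, the estimate is 18000 nM, with an expected range from 6000 nM to 45000 nM.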

Compound 3, half-maximal cytotoxic concentration: 14400 nM
Beside the measured number, compound 3's estimate is 1.3-fold (0.10 log units) above it, within the range that was stated.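

In this assay, amino in place of hydrogen on this aromatic carbon, para to the (4-cyanophenyl)amino group and meta to the existing amino group, gives a 1.7-fold lower number from compound 2 to compound 3 (0.24 log units; within the scatter). This is the only step shown between two actual numbers, and it indicates that this position takes an added amino group without a change that can be told from the scatter. Compound 1 stands at a limit of the assay: the limit of > 48700 nM in this assay, at which 1 of the 3 values shown sits.

The compounds shown leave open how a hydroxyl, a methoxy group or a carboxylic acid on this carbon would read. On these data alone, whether a longer chain on the added amino nitrogen would move the number beyond the scatter also remains open.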